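A few compounds are considered here, and "the series" means these few. Any claim that something is new, unique, unknown or untested is made for them only; others in the source may bear on it.

Measured in a functional assay on SMMC-7721 cells (Homo sapiens) for antiproliferative activity, read by MTT assay, with a stated time of 48 h; on this read-out higher numbers stand for weaker inhibition and lower numbers for stronger inhibition:
- compound 1 `CC(C)=CCC[C@]1(C)/C=C/[C@@H](OC(=O)C=C(C)C)[C@](C)(O)/C=C/C(=O)/C(CCl)=C\C1`: 840 nM
- compound 2 `CC(C)=CCC[C@]1(C)/C=C/[C@@H](OC(=O)C=C(C)C)[C@](C)(O)/C=C/C(=O)/C(CN(C(C)C)C(C)C)=C\C1`: 340 nM
- compound 3 `COCOC/C1=C/C[C@](C)(CCC=C(C)C)/C=C/[C@@H](OC(=O)C=C(C)C)[C@](C)(O)/C=C/C1=O`: 3250 nM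

Of these three, compound 3 has the highest number, 3250 nM, and so inhibits most weakly. Compound 4 `CC(C)=CCC[C@]1(C)/C=C/[C@@H](OC(=O)C=C(C)C)[C@](C)(O)/C=C/C(=O)/C(C(=O)N(C)C)=C\C1` carries dimethylcarbamoyl in place of (methoxymethoxy)methyl on a double-bonded ring carbon. Among the measured compounds shown here, two measured steps bear on this change, as both alter the group at this place: a 3.9-fold higher number from compound 1 to compound 3 (0.59 log units; beyond the scatter) and a 9.6-fold higher number from compound 2 to compound 3 (0.98 log units; beyond the scatter). Both end at the methoxymethoxy compound with a higher number, so the other two groups gave lower numbers. For the measured compounds named here, no measured compound carries dimethylcarbamoyl, which leaves the size uncertain. A modest drop in this assay is expected, an estimated 2.2-fold lower number from compound 3 to compound 4 (0.34 log units; beyond the scatter). For compound 4 the estimate is 1500 nM, with an expected range of 450 nM to 4500 nM.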

Compound 4, half-maximal inhibitory concentration: 3670 nM
Compound 4: middle estimate off by 2.4-fold (0.39 log units), on the low side; the range from low to high includes it.
By their numbers in this assay, from the lowest: compound 2; then compound 1; then compounds 3 and 4 (each within the scatter of the next).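

In this assay, dimethylcarbamoyl and (methoxymethoxy)methyl cannot be told apart on this double-bonded ring carbon, with a 1.1-fold higher number from compound 3 to compound 4 (0.05 log units; within the scatter). Against the other two groups, the new compound shows a 4.4-fold higher number from compound 1 to compound 4 (0.64 log units; beyond the scatter) and an 11-fold higher number from compound 2 to compound 4 (1.03 log units; beyond the scatter), so a second, different group now joins the higher-number end of this small series. Nothing measured here explains these differences.

From the compounds shown here alone, whether a morpholine ring or a smaller amine such as dimethylamino on the methyl carbon would match compound 2 stays open. So does the effect of a carboxylic acid at this place.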